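The source may report more compounds than this note shows. Statements on the series, on what has been measured and on what is new or still open speak of the compounds shown alone.

In a functional assay on MV4-11 cells (Homo sapiens) for antiproliferative activity, read by luminescence and CellTiter-Glo, with a stated time of 72 h (on this read-out lower numbers stand for stronger inhibition and higher numbers for weaker inhibition), compound 1 `Cc1noc(C)c1-c1ccc2c(Nc3ccc(F)cc3)nn(C3CCCCO3)c2c1` gives 9900 nM, compound 2 `Cc1ccc(Cn2nc(Nc3ccc(F)cc3)c3ccc(-c4c(C)noc4C)cc32)cc1` is entered as "not determined" (no result reported) and compound 3 `COc1ccc(Cn2nc(Nc3ccc(F)cc3)c3ccc(-c4c(C)noc4C)cc32)cc1` gives 9100 nM, which places compound 3 level with compound 1. Compound 4 `COc1ccc(Cn2nc(Nc3cccc(C(C)C)c3)c3ccc(-c4c(C)noc4C)cc32)cc1` carries 3-isopropylphenyl in place of the 4-fluorophenyl of compound 3, on a nitrogen on an aromatic ring: 3-isopropylphenyl in place of 4-fluorophenyl on a nitrogen on an aromatic ring. For the measured compounds named here, the only measured step, a 1.1-fold lower number from compound 1 to compound 3 (0.04 log units; within the scatter), swaps oxan-2-yl for 4-methoxybenzyl at a different place, so it does not test this change. Going by the values given here, no measured pair varies the (4-fluorophenyl)amino group, and the direction is open. No step beyond the scatter is therefore expected in this assay, though with wide uncertainty. The expected step is a 1.5-fold lower number from compound 3 to compound 4 (0.18 log units; within the scatter). The estimate for compound 4 is 6000 nM, with an expected range of 1500 nM to 20000 nM.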

Compound 4, half-maximal inhibitory concentration: 8100 nM
Compound 4: middle estimate off by 1.4-fold (0.13 log units), on the low side; low and high end bracket the measured number.
By their numbers in this assay, from the lowest: compounds 4, 3 and 1 (each within the scatter of the next).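

In this assay, this first change to the (4-fluorophenyl)amino group gives a 1.1-fold lower number from compound 3 to compound 4 (0.05 log units; within the scatter), so 3-isopropylphenyl and 4-fluorophenyl on this nitrogen cannot be told apart with the 4-methoxybenzyl group in place. This is a single pair, and it sets no trend for the position. No available evidence explains the result.

Still open, as far as these compounds go, is whether an amine or a carboxylic acid on this phenyl ring would give a step beyond the scatter. Also open, from the compounds shown here alone, is whether the same swap stays flat with oxan-2-yl in place of 4-methoxybenzyl.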